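The source may hold more compounds than are shown below. What is called first, only, known or untested is meant among the compounds shown, and "the series" means these compounds.

Compounds measured so far:
compound 1, `CC1=C(C(=O)SC(C)C)C(c2ccco2)NC(=O)N1`, 5% in an assay on membranes from CHO cells for displacement of a labelled ligand from adenosine receptor A1 (Homo sapiens), read by scintillation counting, with a stated time of 60 min, tested at 1 uM; on this read-out lower numbers stand for less inhibition and higher numbers for more inhibition at the one concentration tested (going by the name of the read-out)
compound 2, `CCC(C)OC(=O)C1=C(C)NC(=O)NC1c1ccco1`, 6% in this assay

Both numbers sit near the bottom of the read-out, and compound 2 is separated from compound 1 only by a step of a number 1 percentage points higher from compound 1 to compound 2 (within the scatter), so the two compounds cannot be told apart on these data. Exchanging isopropylsulfanyl for sec-butoxy on the carbonyl carbon thus left the read-out where it was.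

Compound 3, `CC1=C(C(=O)OCC2CC2)C(c2ccco2)NC(=O)N1`, is not yet measured. It differs from compound 2 by cyclopropylmethyl in place of sec-butyl on an oxygen next to a carbonyl group. Within the data shown here, no measured step touches the ester alkyl chain itself; the only step known, a number 1 percentage points higher from compound 1 to compound 2 (within the scatter), concerns a different part of the same carbonyl-bound group and was flat. On that basis no movement beyond the scatter is expected for compound 3 in this assay, and the step from compound 2 is estimated as no change at the digits printed from compound 2 to compound 3 (within the scatter).

Compound 3 is therefore expected to give about 6% in this assay, within a range from -6% to 18%.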

Compound 3, a percentage reported as inhibition, at one concentration (the size of the read-out at that concentration, not a potency): 29%
Beside the measured number, compound 3's estimate is 23 percentage points below it; the measured number lies above the stated range.
By their numbers in this assay, from the lowest: compounds 1 and 2 (each within the scatter of the next); then compound 3.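

In this assay the group on the oxygen next to a carbonyl group does register: cyclopropylmethyl in place of sec-butyl gives a number 23 percentage points higher from compound 2 to compound 3 (beyond the scatter), although the two groups have the same number of heavy atoms and differ in that the entering one holds a three-membered ring. Cyclopropylmethoxy in place of isopropylsulfanyl on the carbonyl carbon gives a number 24 percentage points higher from compound 1 to compound 3 (beyond the scatter), so the flat exchange between compound 1 and compound 2 does not show this carbonyl-bound group to be without influence on the read-out. Nothing measured here bears on why this change moves the number.

Open, from the compounds shown here alone, is whether a straight butyl chain or cyclobutylmethyl on the same oxygen would read like compound 2 or like compound 3. Also open, going by these compounds, is whether cyclopropylmethyl would keep this read-out with sulfur in place of the oxygen.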